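A few compounds are considered here, and "the series" means these few. Any claim that something is new, unique, unknown or untested is made for them only; others in the source may bear on it.

Working notes on the series.

Compound 1 `CNC(=O)[C@@H]1CCCN1S(=O)(=O)c1ccc(Cl)c(COc2cccc3c(C(F)(F)F)cc(C)nc23)c1Cl` is the reference. For the measured compounds named here, in an ADME assay on microsomes (Homo sapiens) for metabolic stability (on this read-out lower numbers stand for slow clearance and higher numbers for fast clearance), compound 1 gives 250 mL/min/kg, the highest of the two numbers measured so far. Its nearest neighbour is compound 2 `Cc1cc(C(F)(F)F)c2cccc(OCc3c(Cl)ccc(S(=O)(=O)N4CCC[C@H]4C(N)=O)c3Cl)c2n1`, which in this assay gives 167 mL/min/kg; the step of a 1.5-fold lower number from compound 1 to compound 2 (0.18 log units; within the scatter) is within the scatter, so no order between the two is claimed.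

The new member is compound 3 `Cc1cc(C(F)(F)F)c2cccc(OCc3c(Cl)ccc(S(=O)(=O)N4CCC(C#N)CC4)c3Cl)c2n1`. The change from compound 1 is 4-cyanopiperidin-1-yl in place of 2-(methylcarbamoyl)pyrrolidin-1-yl on a sulfonyl sulfur. Going by the values given here, none of the measured steps covers this change: the only step available, a 1.5-fold lower number from compound 1 to compound 2 (0.18 log units; within the scatter), alters just the amide-type nitrogen and leaves the five-membered ring in place, and it was within the scatter. Among the compounds with values here, with no step bearing on the replacement of the whole ring, the expectation rests on compound 1 alone.

Compound 3 is therefore expected at 190 mL/min/kg, range 80 mL/min/kg to 400 mL/min/kg, in this assay. The expected step of a 1.3-fold lower number from compound 1 to compound 3 (0.12 log units; within the scatter) is meant as no change beyond the scatter, with the range left wide because the measured data give no guide for this change.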

Compound 3, clearance: 433 mL/min/kg
Compound 3: the middle estimate sits 2.3-fold (0.36 log units) below what was measured; the whole stated range lies below it.
By their numbers in this assay, from the lowest: compounds 2, 1 and 3 (each within the scatter of the next, the first and the last beyond it).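

The replacement of the whole ring on the sulfonyl sulfur can now be read: in this assay, the step is a 1.7-fold higher number from compound 1 to compound 3 (0.24 log units; within the scatter), so 4-cyanopiperidin-1-yl and 2-(methylcarbamoyl)pyrrolidin-1-yl are not separated. Against 2-carbamoylpyrrolidin-1-yl the step is a 2.6-fold higher number from compound 2 to compound 3 (0.41 log units; beyond the scatter), the first separation seen at this position, though it is modest and rests on this one pair. Nothing measured here accounts for the difference.

Ring size and ring substituent change together in both steps, so the share of each remains open. An unsubstituted piperidin-1-yl, or a pyrrolidin-1-yl carrying a carboxylic acid in place of the amide, would be needed to tell the nitrile, the amide and the ring apart in this assay.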